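The compounds below may be only part of what the source reports. "The series", "measured", "known", "first", "only" and "open" are said of these compounds alone.

In a functional assay on HeLa cells (Homo sapiens) for inhibition, read by CCK-8 assay, with a stated time of 72 h, tested at 1 uM (a lower number here means less inhibition of growth, a higher number more inhibition of growth at the concentration tested), compound 1 `CN(C)C(=O)c1cc2cnc(Nc3ccc(NC(=O)C4(C(=O)Nc5cccc(O)c5)CC4)cc3)nc2n1C1CCCC1` gives 57%, the higher of the two numbers available and beyond the usual scatter from compound 2 `Nc1ccc(NC(=O)C2(C(=O)Nc3ccc(F)cc3)CC2)cc1F`, which gives 14%. Compound 3 `CN(C)C(=O)c1cc2cnc(Nc3ccc(NC(=O)C4(C(=O)Nc5ccc(O)cc5)CC4)cc3)nc2n1C1CCCC1` matches compound 1 except for one change: 4-hydroxyphenyl in place of 3-hydroxyphenyl on an amide-type nitrogen. Going by the values given here, no measured pair shows what this change does, so no step beyond the scatter is expected, and neither direction is favoured. The expected step is a number 5 percentage points lower from compound 1 to compound 3 (within the scatter). For compound 3 the estimated value is 52%, with an expected range of 33% to 70%.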

Compound 3, percent growth inhibition at one concentration: 62.3%
Estimate against measurement, compound 3: 10.3 percentage points below; the measured number falls inside the stated range.
By their numbers in this assay, from the lowest: compound 2; then compounds 1 and 3 (each within the scatter of the next).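

Putting 4-hydroxyphenyl in place of 3-hydroxyphenyl on the amide-type nitrogen gives, in this assay, a number 5.3 percentage points higher from compound 1 to compound 3 (within the scatter), so at this single concentration the two groups cannot be told apart. Going by these compounds alone, this is the first direct comparison at this position, and it shows that this change leaves the growth inhibition within the usual scatter. No available evidence bears on this result. Still open, on these data alone, is whether the hydroxyl group matters at all, which plain phenyl would address, and what 4-aminophenyl or 4-carboxyphenyl would do at this place.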